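Trading an Ethyl for a Vinyl on Compound 2

The compounds below may be only part of what the source reports. "The series", "measured", "known", "first", "only" and "open" are said of these compounds alone.

In a functional assay on PC-3 cells (Homo sapiens) for cytotoxicity, read by MTT assay, with a stated time of 72 h (a higher number here means a weaker inhibitor of growth, a lower number a stronger inhibitor of growth), three compounds have been measured. Compound 1 `COc1ccc(OC(=O)Nc2ccc([Se]C#N)cc2)cc1` gives 7500 nM, compound 2 `CCCOC(=O)Nc1ccc([Se]C#N)cc1` gives 21100 nM, and compound 3 `CCOC(=O)Nc1ccc([Se][Se]c2ccc(NC(=O)OCC)cc2)cc1` gives 28800 nM. Compound 2 thus stands second highest of the three; its number lies close to that of compound 3, within the scatter, while compound 1 sits at a lower number beyond the scatter. Compound 4 `C=CCOC(=O)Nc1ccc([Se]C#N)cc1` is not yet measured. It differs from compound 2 by vinyl in place of ethyl on a saturated chain carbon bound to an oxygen next to a carbonyl group. For the measured compounds named here, no pair of measured compounds separates ethyl from vinyl, so the data give no guide to the size of this change. Only a small shift is expected, none beyond the scatter of this assay. For compound 4 the estimate is 18000 nM, with a range from 8000 nM to 45000 nM. The step expected from compound 2 to compound 4 is then a 1.2-fold lower number from compound 2 to compound 4 (0.07 log units; within the scatter).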

Compound 4, concentration for 50% growth inhibition: 17600 nM
Beside the measured number, compound 4's estimate is 1.0-fold (0.01 log units) above it, within the range that was stated.
By their numbers in this assay, from the lowest: compound 1; then compounds 4, 2 and 3 (each within the scatter of the next).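

In this assay, vinyl in place of ethyl on a saturated chain carbon bound to an oxygen next to a carbonyl group gives a 1.2-fold lower number from compound 2 to compound 4 (0.08 log units; within the scatter). For the compounds shown here, this is the only direct comparison at this position, and it shows that propyl to allyl, which adds one double bond outside aromatic rings, stays within the scatter. No measured evidence bears on this result. From the compounds shown here alone, whether a longer chain or an amine in place of allyl would give a step beyond the scatter remains open, as does whether this change would behave alike on another core.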